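A few compounds are considered here, and "the series" means these few. Any claim that something is new, unique, unknown or untested is made for them only; others in the source may bear on it.

Compound 3 `CN1CCN(C(=O)C2CCN(C(=O)c3ccc(S(C)(=O)=O)c([N+](=O)[O-])c3)CC2)CC1` is the starting point here. In an assay on isolated protein for inhibition of vitamin D3 receptor (Homo sapiens), read by fluorescence polarization (on this read-out higher numbers stand for weaker inhibition and lower numbers for stronger inhibition), compound 3 gives > 60000 nM, which is a limit of the assay rather than a number. Compound 1 `CS(=O)(=O)c1ccc(C(=O)N2CCC(C(=O)N3CCN(c4ccc(F)cc4)CC3)CC2)cc1[N+](=O)[O-]` and compound 2 `Cc1ccc(N2CCN(C(=O)C3CCN(C(=O)c4ccc(S(C)(=O)=O)c([N+](=O)[O-])c4)CC3)CC2)cc1` carry a 4-fluorophenyl or a 4-methylphenyl on the amine nitrogen in the ring where compound 3 carries a methyl. Compound 1 gives > 60000 nM, a limit. Compound 2 gives > 60000 nM, also a limit. Because of the limit of > 60000 nM in this assay, at which 3 of the 3 values shown sit, the steps a step that the two limits leave unreadable from compound 1 to compound 3 and a step that the two limits leave unreadable from compound 2 to compound 3 cannot be sized. Compound 4 `CS(=O)(=O)c1ccc(C(=O)N2CCC(C(=O)N3CCN(c4ccccc4)CC3)CC2)cc1[N+](=O)[O-]` differs from compound 3 by phenyl in place of methyl on an amine nitrogen in a ring. Both measured steps toward aryl groups bear on this change, yet neither shows a readable size. Compound 4 is therefore expected to stay at the limit, with an estimate of 80000 nM (range 20000 nM to 300000 nM) and an expected step that the limit leaves unreadable from compound 3 to compound 4.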

Compound 4, half-maximal inhibitory concentration: > 60000 nM
Compound 4: no number, only a limit (the forecaster's own chance of this, stated with the estimate: 90%); the middle value is on the limit's open side.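

No step can be read between compound 4 and compound 1, compound 2 or compound 3, because each value is a limit and not a number: the limit of > 60000 nM in this assay, at which 4 of the 4 values shown sit.

The compounds shown leave open whether methyl, phenyl, 4-fluorophenyl or 4-methylphenyl on the ring amine nitrogen makes any difference in this assay.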